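Acyl chain truncation across two trifluoromethyl anilide cores

This account rests on a few compounds, and the source may have more. Where it says the series, first, only, none or still open, it means among the compounds named here.

Compound 1 `CCCCCCCCC(=O)N1c2ccccc2CCC1C(=O)Nc1ccccc1C(F)(F)F` and compound 3 `CCCCCCCCC(=O)N1c2ccccc2CCC1C(=O)Nc1cc(C(F)(F)F)cc(C(F)(F)F)c1` both carry the octylcarbonyl chain; the difference between their two cores is not broken down here. In a functional assay on NCI-H23 cells (Homo sapiens) for cytotoxicity, read by sulforhodamine B assay, with a stated time of 72 h (on this read-out higher numbers stand for weaker inhibition of growth and lower numbers for stronger inhibition of growth), compound 1 gives 4220 nM and compound 3 gives 3230 nM, values within the scatter of each other. Compound 2 `CCC(=O)N1c2ccccc2CCC1C(=O)Nc1ccccc1C(F)(F)F` is compound 1 with hydrogen in place of hexyl on a saturated chain carbon, two bonds along the chain from a carbonyl carbon. In this assay compound 2 reaches only > 80000 nM, which is a limit and not a number. The step of an at least 18-fold higher number from compound 1 to compound 2 (1.27 log units; beyond the scatter) thus ends at the limit of > 80000 nM in this assay, at which 1 of the 3 values shown sits. Compound 4 `CCC(=O)N1c2ccccc2CCC1C(=O)Nc1cc(C(F)(F)F)cc(C(F)(F)F)c1` is compound 3 with hydrogen in place of hexyl on a saturated chain carbon, two bonds along the chain from a carbonyl carbon, the same change. The step from compound 3 to compound 4 in this assay is expected to be of like size, a 22-fold higher number from compound 3 to compound 4 (1.34 log units; beyond the scatter), resting on an at least 18-fold higher number from compound 1 to compound 2 (1.27 log units; beyond the scatter). Compound 4 is therefore expected to give about 70000 nM, quite possibly only a limit again.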

Compound 4, concentration for 50% growth inhibition: 7820 nM
The estimate for compound 4 lay 9.0-fold (0.95 log units) above the measured number, and the stated range ends above it.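

In this assay, the change from octylcarbonyl to propanoyl gives a 2.4-fold higher number from compound 3 to compound 4 (0.38 log units; beyond the scatter), so the direction carries from one core to the other but the size does not: the same change on two cores in this assay, an at least 18-fold higher number (1.27 log units; beyond the scatter) from compound 1 to compound 2 and a 2.4-fold higher number (0.38 log units; beyond the scatter) from compound 3 to compound 4, at least 7.8-fold (0.89 log units) apart, beyond the scatter of two such steps. Compound 2 gives > 80000 nM, which is a limit and not a number. With a single pair on each core, these results do not show which part of the cores sets the gap, nor whether it would hold for other chains.

Open, as far as these compounds go, is how the values run for chains of intermediate length, such as butanoyl or hexanoyl, on each core. Also open, from the compounds shown here alone, is how a longer chain, or a chain ending in an amine or a carboxylic acid, would read.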